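Ring substituent on the thiazolidinone nitrogen: compound 2 to 3

The source may hold more compounds than are shown below. What is called first, only, known or untested is meant among the compounds shown, and "the series" means these compounds.

Going by the values given here, compound 2 `CCN1C(=O)CSC1c1cccc(C(=O)NCCCCc2ccccc2)c1` gives 0% in a functional assay on HOS-TE85 cells (Homo sapiens) for inhibition, read by CCK-8 assay, with a stated time of 72 h, tested at 1 uM (on this read-out lower numbers stand for less inhibition and higher numbers for more inhibition at the one concentration tested (going by the name of the read-out)), the lowest of the two numbers measured so far. The nearest measured compound is compound 1 `COc1ccc(F)cc1N1C(=O)CSC1c1cccc(C(=O)NCCCCc2ccccc2)c1`, which in this assay gives 95%. Among the compounds with values here, the single measured step, a number 95 percentage points lower from compound 1 to compound 2 (beyond the scatter), is large and replaces 5-fluoro-2-methoxyphenyl by ethyl on the amide-type nitrogen in the ring.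

Compound 3 `CC(F)(F)c1cccc(N2C(=O)CSC2c2cccc(C(=O)NCCCCc3ccccc3)c2)c1` changes compound 2 at that same place: a group of 10 heavy atoms (8 carbon, 2 fluorine; one six-membered aromatic ring of carbon only) in place of a group of 2 heavy atoms (2 carbon; no ring), on an amide-type nitrogen in a ring. Within the data shown here, the ethyl that leaves is the group whose introduction coincided with the large loss in a number 95 percentage points lower from compound 1 to compound 2 (beyond the scatter); the entering group, like the one in compound 1, carries one six-membered aromatic ring of carbon only, whereas ethyl has no ring.

Among the measured compounds shown here, only the step from compound 1 to compound 2 bears on this change, so a large rise is expected in this assay from compound 2 to compound 3, estimated as a number 80 percentage points higher from compound 2 to compound 3 (beyond the scatter). Whether the two fluorines on a carbon in the new group and the different substitution pattern matter cannot be told from two compounds. Compound 3 is therefore estimated at 80% in this assay, with a range of 40% to 98%.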

Compound 3, a percentage reported as inhibition, at one concentration (the size of the read-out at that concentration, not a potency): 93%
Compound 3: middle estimate off by 13 percentage points, on the low side; measured number inside the range.
By their numbers in this assay, from the lowest: compound 2; then compounds 3 and 1 (each within the scatter of the next).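

In this assay the contrast between ethyl and a group carrying a six-membered aromatic ring of carbon only, on the amide-type nitrogen in the ring, now rests on two pairs instead of one: the exchange gives a number 93 percentage points higher from compound 2 to compound 3 (beyond the scatter) and so matches the earlier large step in the opposite direction. The two ring-bearing groups, by contrast, are not separated by this read-out: the change gives a number 2 percentage points lower from compound 1 to compound 3 (within the scatter) even though the entering group has two fluorines on a carbon, no oxygen and a different substitution pattern, so at this position the read-out at one concentration does not depend on those particular ring substituents. Nothing measured on hand explains either step.

As far as these compounds go, whether the aromatic ring itself matters, or only the larger size of the group, stays open, and a cyclohexyl group or a longer chain such as hexyl on the same nitrogen would address that. A single concentration also cannot show whether compound 1 and compound 3 differ in potency, and the response to a pyridine ring or an amine on the aromatic ring is likewise unknown.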